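From fluoro to trifluoromethyl: compound 2 and compound 4

This account rests on a few compounds, and the source may have more. Where it says the series, first, only, none or still open, it means among the compounds named here.

Measured in a functional assay on HepG2 cells (Homo sapiens) for cytotoxicity, read by MTT assay, with a stated time of 72 h; on this read-out higher numbers stand for weaker inhibition and lower numbers for stronger inhibition:

Compound 1 `CCOC(=O)C(COC(=O)c1ccccc1OC(C)=O)c1ccc(F)cc1`: > 0.01 ug/mL (a limit)
Compound 2 `CCOC(=O)C(COC(=O)/C=C/c1ccc(OC)c(OC)c1)c1ccc(F)cc1`: > 0.01 ug/mL (a limit)
Compound 3 `CCOC(=O)C(COC(=O)c1ccccc1)c1ccc(C(F)(F)F)cc1`: > 0.01 ug/mL (a limit)

None of these three compounds has yet given a number in this assay. What they share is the limit of > 0.01 ug/mL in this assay, at which 3 of the 3 values shown sit.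

Going by these compounds, compound 2 gives only a limit, > 0.01 ug/mL, so its true position on the scale remains open. Compound 4 `CCOC(=O)C(COC(=O)/C=C/c1ccc(OC)c(OC)c1)c1ccc(C(F)(F)F)cc1` is not yet measured and differs from compound 2 in one place: trifluoromethyl in place of fluoro on an aromatic carbon. Here, trifluoromethyl stands in place of fluoro on an aromatic carbon, para to a large group.

Among the measured compounds shown here, no two measured compounds differ in one place only, so the series offers no measured step for this change. Compound 3, which carries the 4-(trifluoromethyl)phenyl group, also gives only a limit, > 0.01 ug/mL. In this assay, no step beyond the scatter is expected in either direction, and a further limit is the likeliest report for compound 4. Put as a number, the expected change is a step that the limit leaves unreadable from compound 2 to compound 4. For compound 4 the estimated value is 0.02 ug/mL, with an expected range of 0.01 ug/mL to 0.1 ug/mL.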

Compound 4, half-maximal inhibitory concentration: > 0.01 ug/mL
Compound 4: no number, only a limit; the forecaster's own chance of this, stated with the estimate: 85%; the middle value is on the limit's open side.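

Compound 4, like compound 2, gives only a limit in this assay, so no step can be read for trifluoromethyl in place of fluoro on an aromatic carbon. The compounds shown have one result in common: the limit of > 0.01 ug/mL in this assay, at which 4 of the 4 values shown sit.

They leave open where any of them stands on the scale in this assay, and whether this change shifts the value at all.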